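Lengthening the ester chain of a dihydropyridine calcium channel antagonist

A few compounds are considered here, and "the series" means these few. Any claim that something is new, unique, unknown or untested is made for them only; others in the source may bear on it.

Measured compounds:
Compound 1 `CCOC(=O)C1=C(C)NC(CN2CCN(c3ccccc3)CC2)=C(C(=O)OCC)C1c1cccc([N+](=O)[O-])c1` gives 630 nM in a functional assay on HEK293 cells for antagonist activity at Voltage-dependent L-type calcium channel subunit alpha-1C (Oryctolagus cuniculus), read by FLIPR; on this read-out higher numbers stand for weaker inhibition and lower numbers for stronger inhibition.
Compound 2 `COC(=O)C1=C(C)NC(C)=C(C(=O)OCc2ccccc2)C1c1cccc([N+](=O)[O-])c1` gives 25 nM in this assay.
Compound 3 `CCOC(=O)C1=C(C)NC(C)=C(C(=O)OCc2ccc([N+](=O)[O-])cc2)C1c1cccc([N+](=O)[O-])c1` gives 130 nM in this assay.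

Compound 2 has the lowest number of the three, and both gaps lie beyond the scatter, so it is the strongest inhibitor here. Compound 3 comes nearest, compound 1 is furthest away.

Compound 4 `COC(=O)C1=C(C)NC(C)=C(C(=O)OCCCCc2ccccc2)C1c1cccc([N+](=O)[O-])c1` has not yet been measured in this assay. It differs from compound 2 in one place: 3-phenylpropyl in place of phenyl on a saturated chain carbon bound to an oxygen next to a carbonyl group. The 3-phenylpropyl thus takes the position of the phenyl on the saturated chain carbon bound to an oxygen next to the carbonyl group.

Among the measured compounds shown here, no measured pair shows this kind of change, so the expectation rests on compound 2 alone. The step from compound 2 to compound 4 is expected to be small, a 1.6-fold higher number from compound 2 to compound 4 (0.20 log units; within the scatter), toward a slightly higher number, likely within the scatter. Compound 4 is therefore estimated at 40 nM, with a range from 10 nM to 160 nM.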

Compound 4, half-maximal inhibitory concentration: 10 nM
Compound 4: middle estimate off by 4.0-fold (0.60 log units), on the high side; the measured number falls inside the stated range.
By their numbers in this assay, from the lowest: compound 4; then compound 2; then compound 3; then compound 1.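

In this assay, exchanging the phenyl on the saturated chain carbon for 3-phenylpropyl, which turns the benzyl ester into a 4-phenylbutyl ester, gives a 2.5-fold lower number from compound 2 to compound 4 (0.40 log units; beyond the scatter). Among the compounds shown here, until now no two measured compounds differed in only one place, so this is the first direct reading of a single change here: the step is modest, but the longer chain is tolerated and inhibition gets stronger rather than weaker. No measurement at hand explains this gain.

Going by these compounds, only the benzyl and 4-phenylbutyl esters can be compared, so it stays open whether 2-phenylethyl would fall between them or whether 5-phenylpentyl would extend the gain or reverse it. Also open, on these data alone, is whether the phenyl is needed at all, a question that a chain ending in an amine or a carboxylic acid could answer.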